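Swap of the five-membered aromatic ring for phenyl, cytotoxicity

A few compounds are considered here, and "the series" means these few. Any claim that something is new, unique, unknown or untested is made for them only; others in the source may bear on it.

Three compounds of the series have been examined in an ADME assay on HEK293 cells (Homo sapiens) for cytotoxicity, read by CCK-8 assay and cell counting, with a stated time of 2 days; on this read-out higher numbers stand for weaker inhibition and lower numbers for stronger inhibition. Compound 1 `Oc1cccc(-c2cc(-c3ccncc3)nc(-c3ccccc3Cl)c2)c1` gives "not determined" (no result reported) in this assay, so it adds nothing to the numbers. Compound 2 `Oc1ccc(-c2cc(-c3ccccc3)nc(-c3ccccc3Cl)c2)cc1` gives 3930 nM in this assay. Compound 3 `Oc1cccc(-c2cc(-c3ccsc3)nc(-c3ccccc3Cl)c2)c1` gives 2720 nM in this assay, the lowest of the two numbers on hand; the nearest value is that of compound 2, and the gap between the two is within the scatter, so no order between compound 2 and compound 3 can be read from them.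

The next compound is compound 4 `Oc1cccc(-c2cc(-c3ccccc3)nc(-c3ccccc3Cl)c2)c1`. Its difference from compound 3 is phenyl in place of thiophen-3-yl on an aromatic carbon on an aromatic carbon of the six-membered aromatic ring with one nitrogen, next to the ring nitrogen. Among the compounds with values here, no step between two measured compounds matches this change, so its effect in this assay is unknown here; only the closeness of compound 2 and compound 3 speaks, and it points to no movement beyond the scatter. The step from compound 3 to compound 4 is expected to be small, a 1.3-fold higher number from compound 3 to compound 4 (0.10 log units; within the scatter), with no preferred direction. Compound 4 is therefore estimated at 3400 nM in this assay, with a range from 1700 nM to 7000 nM.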

Compound 4, half-maximal inhibitory concentration: 1760 nM
For compound 4 the middle estimate is 1.9-fold (0.29 log units) above the measured one; measured number inside the range.
By their numbers in this assay, from the lowest: compounds 4, 3 and 2 (each within the scatter of the next, the first and the last beyond it).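

Working note on the position next to the ring nitrogen: in this assay, phenyl in place of thiophen-3-yl gives a 1.5-fold lower number from compound 3 to compound 4 (0.19 log units; within the scatter), so this measured pair does not separate the two aromatic rings at this position. The change that does register lies elsewhere, on the other aryl substituent of the shared core: 3-hydroxyphenyl in place of 4-hydroxyphenyl gives a 2.2-fold lower number from compound 2 to compound 4 (0.35 log units; beyond the scatter), a modest step and the only one shown that passes the scatter. No measurement here accounts for either step.

Since compound 1 gives "not determined" (no result reported), only phenyl and thiophen-3-yl can be compared at the position next to the ring nitrogen, and the compounds shown leave open whether a non-aromatic group there, such as an amine, a carboxylic acid or a longer alkyl chain, would move the number beyond the scatter. Also open, as far as these compounds go, is whether the hydroxyl step holds with thiophen-3-yl in place of phenyl, and whether a methoxy group in place of the hydroxyl, or a change to the 2-chlorophenyl group, would alter the number.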